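Swapping Formyl for Phenyl on the Ring Nitrogen

A few compounds are considered here, and "the series" means these few. Any claim that something is new, unique, unknown or untested is made for them only; others in the source may bear on it.

Compound 3 `Cc1ccc(C2=NN(C=O)C(c3cn(-c4ccccc4)nc3-c3ccc(Cl)c(Cl)c3)C2)cc1` gives 60.9% in a functional assay on the whole organism (strain Wistar) for inhibition, with Rattus norvegicus as the target, read by paw edema, with stated times of 30 min and 120 min, at a dose of 50 mg/kg by the oral route; on this read-out lower numbers stand for less inhibition and higher numbers for more inhibition at the one dose given (going by the name of the read-out). That is the lowest of the three numbers shown, but the other two lie within the scatter of it: compound 2 `Clc1ccc(C2=NN(c3ccccc3)C(c3cn(-c4ccccc4)nc3-c3ccc(Cl)c(Cl)c3)C2)cc1` gives 61.7%, and compound 1 `CCC(=O)N1N=C(c2ccc(C)cc2)CC1c1cn(-c2ccccc2)nc1-c1ccc(Cl)c(Cl)c1` gives 70.3%. Among the compounds with values here, the one measured step between compounds differing in a single place, a number 9.4 percentage points lower from compound 1 to compound 3 (within the scatter), also stays within the scatter, so the acyl part on that nitrogen has so far shifted nothing that can be read as real.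

Compound 4 `Cc1ccc(C2=NN(c3ccccc3)C(c3cn(-c4ccccc4)nc3-c3ccc(Cl)c(Cl)c3)C2)cc1` has not been measured. It differs from compound 3 by phenyl in place of formyl on an amine nitrogen in a ring. Within the data shown here, no measured step covers this exchange directly. Compound 2, which already carries a phenyl on that ring nitrogen, gives a number close to compound 3, and the acyl variation between compound 1 and compound 3 moved nothing beyond the scatter. The step of a number 2.1 percentage points higher from compound 3 to compound 4 (within the scatter) is therefore expected to fall within the scatter, with no clear direction. For compound 4 the estimate in this assay is 63%, with a range from 50% to 75%.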

Compound 4, a percentage reported as inhibition, in the whole organism at one dose (the size of the read-out at that dose, not a potency): 62.5%
For compound 4 the middle estimate is 0.5 percentage points above the measured one; measured number inside the range.
By their numbers in this assay, from the lowest: compounds 3, 2, 4 and 1 (each within the scatter of the next).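

In this assay, within the data shown here, the ring nitrogen now carries a phenyl in place of formyl, the first direct exchange of an acyl group for an aromatic ring at this position, and the step is a number 1.6 percentage points higher from compound 3 to compound 4 (within the scatter). The same holds against the larger acyl group, with phenyl in place of propanoyl giving a number 7.8 percentage points lower from compound 1 to compound 4 (within the scatter), while on the other side of the core, methyl in place of chloro on an aromatic carbon gives a number 0.8 percentage points higher from compound 2 to compound 4 (within the scatter), so none of these exchanges yet shows a readable effect. Nothing available explains why these steps stay so small.

The compounds shown leave open whether a carboxylic acid or an amine on that ring nitrogen, or an acyl chain longer than propanoyl, would move the number beyond the scatter. They also leave open whether a methoxy group in place of the methyl would do so.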